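Fluorine placement on the benzylsulfanyl arm: compound 4

The compounds below may be only part of what the source reports. "The series", "measured", "known", "first", "only" and "open" are said of these compounds alone.

Measured so far in an assay on isolated protein for inhibition of Alpha glucosidase (Homo sapiens), read by spectrophotometry, with stated times of 15 min and 30 min; on this read-out higher numbers stand for weaker inhibition and lower numbers for stronger inhibition:
compound 1 `Fc1cccc(CSc2nc(-c3ccc(Br)cc3)cc(-c3cccc(Br)c3)n2)c1` gives 19000 nM
compound 2 `Fc1ccccc1CSc1nc(-c2ccc(Br)cc2)cc(-c2ccc(Br)cc2)n1` gives 19000 nM
compound 3 `Fc1ccc(CSc2nc(-c3ccc(Br)cc3)cc(-c3ccc(Br)cc3)n2)cc1` gives 19000 nM

Compound 3 stands level with compound 1 and compound 2 at the digits shown; all three values lie within the scatter of one another, so no order among them can be read.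

The next compound, compound 4 `Fc1cccc(CSc2nc(-c3ccc(Br)cc3)cc(-c3ccc(Br)cc3)n2)c1`, differs from compound 3 only in 3-fluorophenyl in place of 4-fluorophenyl on a saturated chain carbon bound to a sulfur.

Among the compounds with values here, one measured step bears directly on this: no change at the digits printed from compound 2 to compound 3 (within the scatter). Moving the fluorine from one place on the benzyl ring to another left this assay unchanged. Compound 1 carries the same 3-fluorophenyl group that enters in compound 4, but it also differs from compound 3 on one of the bromophenyl rings, so only the two values can be set side by side; they are the same at the digits shown. Nothing in the series therefore points to a step in this assay beyond the scatter, in either direction.

Compound 4 is accordingly expected to give 19000 nM in this assay, with a range of 9500 nM to 38000 nM. The expected step, no change at the digits printed from compound 3 to compound 4 (within the scatter), is none beyond the scatter.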

Compound 4, half-maximal inhibitory concentration: 19000 nM
Compound 4: the middle estimate sits on the measured number at the digits printed, and the stated range covers the measured number.
By their numbers in this assay, from the lowest: compounds 1, 2, 3 and 4 (each within the scatter of the next).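

With compound 4, the 2-fluorophenyl, 3-fluorophenyl and 4-fluorophenyl groups on a saturated chain carbon bound to a sulfur all stand on an otherwise identical structure, and in this assay the new readings are no change at the digits printed from compound 3 to compound 4 (within the scatter) and no change at the digits printed from compound 2 to compound 4 (within the scatter) so that no placement of the fluorine can be told from another. Compound 4 also gives compound 1 its first partner differing in one place, 4-bromophenyl in place of 3-bromophenyl on an aromatic carbon, and in this assay that comparison reads no change at the digits printed from compound 1 to compound 4 (within the scatter) so the placement of this bromine shows no separation either. No measurement on hand offers an explanation for these level readings.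

Whether the benzyl ring can move the reading at all remains open, as a ring without fluorine, or one with a methoxy group, a hydroxyl group or a carboxylic acid in its place, lies outside the compounds shown. Also open, from the compounds shown here alone, is what would follow from an amine or a chlorine in place of the bromine, or from a longer chain between the sulfur and the ring.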